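A few compounds are considered here, and "the series" means these few. Any claim that something is new, unique, unknown or untested is made for them only; others in the source may bear on it.

Compound 1 `NC(=O)c1c(NC(=O)c2ccccc2Cl)sc2c1CCNC2` gives 18600 nM in a functional assay on HL-60 cells (Homo sapiens) for antiproliferative activity, with a stated time of 24 h; on this read-out lower numbers stand for stronger inhibition and higher numbers for weaker inhibition. Its number is the highest of the three measured here, yet compound 3 `NC(=O)c1c(NC(=O)c2ccccc2F)sc2c1CCN(Cc1ccc(Cl)cc1Cl)C2` with 13100 nM and compound 2 `Cc1ccc(C(=O)Nc2sc3c(c2C(N)=O)CCN(Cc2c(Cl)cccc2Cl)C3)cc1` with 10000 nM both lie within the usual scatter of it, so no order among the three can be read. Compound 4 `NC(=O)c1c(NC(=O)c2ccccc2Cl)sc2c1CCN(C(=S)Nc1ccccc1I)C2` differs from compound 1 by a group of 10 heavy atoms (7 carbon, 1 nitrogen, 1 sulfur, 1 iodine; one six-membered aromatic ring of carbon only) in place of a hydrogen atom, on an amine nitrogen in a ring. Within the data shown here, no measured pair isolates this change. Compound 2 and compound 3 also carry groups on the amine nitrogen in the ring, and their numbers sit close to that of compound 1. A small step is therefore expected, a 2.3-fold lower number from compound 1 to compound 4 (0.37 log units; beyond the scatter), barely beyond the scatter if at all. Compound 4 is estimated at 8000 nM in this assay, with a range from 2500 nM to 25000 nM.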

Compound 4, half-maximal inhibitory concentration: 4430 nM
For compound 4 the middle estimate is 1.8-fold (0.26 log units) above the measured one; the range from low to high includes it.
By their numbers in this assay, from the lowest: compound 4; then compounds 2, 3 and 1 (each within the scatter of the next).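

Placing this group of 10 heavy atoms on the amine nitrogen in the ring gives a 4.2-fold lower number from compound 1 to compound 4 (0.62 log units; beyond the scatter) in this assay and is the first change at this position that can be read on its own. The hydrogen atom on this nitrogen is therefore not needed for activity in these cells, and a large group is accepted there. Nothing measured here explains the gain.

Which part of the group carries the step stays open. A version with bromine in place of iodine, or oxygen in place of sulfur, would help separate these parts.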